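This account rests on a few compounds, and the source may have more. Where it says the series, first, only, none or still open, it means among the compounds named here.

In a functional assay on Right cardiac atrium for agonist activity at histamine H2 receptor (Cavia porcellus), with a stated time of 30 min, in the presence of a further agent that is not named here (on this read-out higher numbers stand for larger maximal responses and lower numbers for smaller maximal responses), compound 3 `Cc1nc(N)sc1CCCN/C(N)=N/C(=O)NC(C)c1ccc(F)cc1` gives 0.92. Among the three measured compounds it carries the lowest number, yet compound 1 `Cc1nc(N)sc1CCCN/C(N)=N/C(=O)NC(C)c1ccc(Cl)cc1` gives 0.93 and compound 2 `CCCCCCNC(=O)/N=C(\N)NCCCc1sc(N)nc1C` gives 0.95, and both of these sit within the scatter of compound 3, so no ordering among the three can be claimed. Within the data shown here, the only measured step that changes a single place, a number 0.010 lower from compound 1 to compound 3 (within the scatter), is itself within the scatter.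

Compound 4 `Cc1nc(N)sc1CCCN/C(N)=N/C(=O)NC(C)c1ccco1` differs from compound 3 by furan-2-yl in place of 4-fluorophenyl on a saturated chain carbon bound to an amide-type nitrogen and a saturated chain carbon. Among the measured compounds shown here, no measured step replaces one aromatic ring by another, so this change has no direct precedent. The nearest guides are the halogen swap between compound 1 and compound 3, which moved the number very little, and compound 2, which bears a quite different group on the amide-type nitrogen and still gives 0.95. The maximal response in this assay is therefore expected to stay essentially where compound 3 stands, with no change at the digits printed from compound 3 to compound 4 (within the scatter) expected to fall within the scatter. Compound 4 is estimated at 0.92, with a range from 0.8 to 1.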

Compound 4, intrinsic activity: the largest response reached, as a fraction of the reference agonist's: 1
Compound 4: the middle estimate sits 0.080 below what was measured, within the range that was stated.
By their numbers in this assay, from the lowest: compounds 3, 1, 2 and 4 (each within the scatter of the next).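

Swapping the ring at this place, on a saturated chain carbon bound to an amide-type nitrogen and a saturated chain carbon, gives in this assay a step of a number 0.080 higher from compound 3 to compound 4 (within the scatter) and, with 4-chlorophenyl as the group leaving, a step of a number 0.070 higher from compound 1 to compound 4 (within the scatter). Among these compounds, until now the only step at this place was a halogen swap, whereas here a six-membered aromatic ring of carbon only gives way to furan-2-yl, a five-membered aromatic ring with 1 hetero atom, and the maximal response stays inside the scatter. Set against hexyl on the amide-type nitrogen, 1-(furan-2-yl)ethyl gives a number 0.050 higher from compound 2 to compound 4 (within the scatter), and nothing at hand explains why this read-out holds across such different groups.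

All of these steps lie within the scatter, so the read-out does not separate the groups shown. From the compounds shown here alone, whether a pyridin-2-yl ring, an amine or a carboxylic acid at this same place would keep the maximal response stays open.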